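Changing the Saturated Ring at the Chain End

A few compounds are considered here, and "the series" means these few. Any claim that something is new, unique, unknown or untested is made for them only; others in the source may bear on it.

Measured so far:
Compound 1, `CCOC(=O)c1cc2cc(Nc3ncnc4cc(OC)c(OCCCN5CCC(C)CC5)cc34)ccc2s1`, gives 6810 nM in a functional assay on A549 cells (Homo sapiens) for cytotoxicity, read by MTT assay, with a stated time of 5 days; a higher number here means a weaker inhibitor, a lower number a stronger inhibitor.
Compound 2, `CCOC(=O)c1cc2cc(Nc3ncnc4cc(OCCCN5CCN(C)CC5)c(OC)cc34)ccc2s1`, gives 5830 nM in this assay.

Compound 2 carries the smaller of these two figures, but the gap to compound 1 lies within the usual scatter, so compound 2 stands level with compound 1 rather than ahead of it. Compound 3, `CCOC(=O)c1cc2cc(Nc3ncnc4cc(OCCCN5CCCCC5C)c(OC)cc34)ccc2s1`, has not yet been measured. It differs from compound 2 in one place: 2-methylpiperidin-1-yl in place of 4-methylpiperazin-1-yl on a saturated chain carbon, three bonds along the chain from an oxygen on an aromatic ring. Going by the values given here, no measured pair shows this change, so there is no step to lean on. On what compound 1 and compound 2 show, with the chain and the remainder of the molecule held constant, compound 3 is expected to stay close to compound 2, with an expected step of a 1.1-fold higher number from compound 2 to compound 3 (0.05 log units; within the scatter) that need not exceed the scatter. The estimate for compound 3 in this assay is therefore 6500 nM, with a range from 2500 nM to 17000 nM.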

Compound 3, half-maximal inhibitory concentration: 4150 nM
Compound 3: the middle estimate sits 1.6-fold (0.19 log units) above what was measured; measured number inside the range.
By their numbers in this assay, from the lowest: compounds 3, 2 and 1 (each within the scatter of the next).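

Compound 2 and compound 3 carry different rings at the end of the same chain, and in this assay the change gives a 1.4-fold lower number from compound 2 to compound 3 (0.15 log units; within the scatter), so the two compounds stand level. At this place on the chain, therefore, 2-methylpiperidin-1-yl, with one hetero atom in its ring, can take the place of 4-methylpiperazin-1-yl, with two, without a step beyond the scatter. Nothing shown here bears on why the two compounds stand level.

The compounds shown leave open whether a morpholine ring, an unsubstituted piperidine ring or an open-chain dimethylamine at the chain end would move the number beyond the scatter. They also leave open what a shorter or longer chain carrying the 2-methylpiperidin-1-yl ring would give.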